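Bromo for Nitro on an Alkyne-Linked Benzonitrile Antagonist

This account rests on a few compounds, and the source may have more. Where it says the series, first, only, none or still open, it means among the compounds named here.

Of the compounds shown here, two have been measured in a functional assay on HEK293 cells for antagonist activity at metabotropic glutamate receptor 5 (Rattus norvegicus), read by calcium flux; a lower number here means a stronger inhibitor, a higher number a weaker inhibitor. Compound 1 `Cc1nc(C#Cc2cc(Cl)cc(C#N)c2)cs1`, which carries a chloro group and a nitrile on its benzene ring, gives 1.61 nM in this assay. Compound 2 `Cc1ccc(C#Cc2cc(C#N)cc([N+](=O)[O-])c2)nc1`, in which a methylpyridine replaces the methylthiazole and a nitro group stands on the benzene ring, gives 2.64 nM. Compound 2 has the higher of the two numbers, but the gap to compound 1 lies within the usual scatter, so the two are not distinguishable on these data.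

Compound 3 `Cc1ccc(C#Cc2cc(Br)cc(C#N)c2)nc1` has not been measured. It differs from compound 2 in one place: bromo in place of nitro on an aromatic carbon. Going by the values given here, no measured pair shows this exchange directly, and the only related clue is that compound 1, with a chloro group on the same kind of ring, gives 1.61 nM. Compound 3 is therefore expected to stay close to compound 2, with a step from compound 2 to compound 3 of a 1.3-fold lower number from compound 2 to compound 3 (0.12 log units; within the scatter), not beyond the scatter. Compound 3 is estimated at 2 nM, with a likely range from 0.7 nM to 6 nM.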

Compound 3, half-maximal inhibitory concentration: 1.02 nM
Estimate against measurement, compound 3: 2.0-fold (0.29 log units) above; low and high end bracket the measured number.
By their numbers in this assay, from the lowest: compounds 3, 1 and 2 (each within the scatter of the next, the first and the last beyond it).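

The change from nitro to bromo sits on an aromatic carbon, meta to a cyano group and meta to a group of 9 heavy atoms, and in this assay it gives a 2.6-fold lower number from compound 2 to compound 3 (0.41 log units; beyond the scatter), a modest step. Going by these compounds alone, this is the first comparison in the set between compounds that differ in one place, and it shows that this position affects the read-out, whereas the gap between the two earlier compounds lay within the scatter and spanned more than one difference. Nitro's 3 heavy atoms and 2 hydrogen-bond acceptors can also give way to a single bromine with no loss of inhibition, although nothing available accounts for the lower number.

The compounds shown leave open how chloro, carried by compound 1, would compare with bromo on the core of compound 3, as compound 1 and compound 3 differ in more than one place. They also leave open how an amine, a methoxy group or a carboxylic acid would read at this position, and so how far the trend from nitro to bromo extends.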